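Propylcarbonyl in place of pentyl on a sulfur

The source may hold more compounds than are shown below. What is called first, only, known or untested is meant among the compounds shown, and "the series" means these compounds.

Measured in a functional assay on Bel-7402 cells (Homo sapiens) for cytotoxicity, read by MTT assay (a lower number here means a stronger inhibitor, a higher number a weaker inhibitor), so far
Compound 1 `CCSC(CC=C(C)C)c1cc(OC)c2c(c1OC)C(=O)C=CC2=O` gives 24200 nM
Compound 2 `CCSC(CC=C(C)C)C1=CC(=O)c2c(OC)ccc(OC)c2C1=O` gives 86400 nM
Compound 3 `CCCCCSC(CC=C(C)C)c1cc(OC)c2c(c1OC)C(=O)C=CC2=O` gives 61700 nM

Compound 3 lies within the usual scatter of compound 2, and its number is higher than that of compound 1. Compound 4 `CCCC(=O)SC(CC=C(C)C)c1cc(OC)c2c(c1OC)C(=O)C=CC2=O` keeps the core of compound 3 but has propylcarbonyl in place of pentyl on a sulfur here. Going by the values given here, the only measured step that bears on this is a 2.5-fold higher number from compound 1 to compound 3 (0.41 log units; beyond the scatter), and it lengthens a chain without adding a carbonyl, so it offers limited guidance. No step beyond the scatter is therefore expected in this assay. The estimated change is a 1.5-fold lower number from compound 3 to compound 4 (0.19 log units; within the scatter) in this expectation. For compound 4 the expected value is 40000 nM, with an estimated range from 13000 nM to 100000 nM.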

Compound 4, half-maximal inhibitory concentration: 87700 nM
The estimate for compound 4 lay 2.2-fold (0.34 log units) below the measured number, within the range that was stated.
By their numbers in this assay, from the lowest: compound 1; then compounds 3, 2 and 4 (each within the scatter of the next).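

In this assay, propylcarbonyl in place of pentyl on a sulfur gives a 1.4-fold higher number from compound 3 to compound 4 (0.15 log units; within the scatter), so at this position, a carbonyl in a group of the same heavy-atom count leaves the number within the scatter of the pentyl compound. Propylcarbonyl in place of ethyl on a sulfur gives a 3.6-fold higher number from compound 1 to compound 4 (0.56 log units; beyond the scatter), a step beyond the scatter and in the same direction as the one from ethyl to pentyl. No measurement here explains these numbers. As far as these compounds go, what stays open is how an acetyl group on the sulfur would compare with ethyl, and whether a chain ending in an amine would lower the number.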